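The source may report more compounds than this note shows. Statements on the series, on what has been measured and on what is new or still open speak of the compounds shown alone.

In an ADME assay on Vero cells (Chlorocebus sabaeus) for cytotoxicity, with a stated time of 72 h (a lower number here means a stronger inhibitor, a higher number a weaker inhibitor), the measured compounds are:

Compound 1 `CCOC(=O)c1cc(/C=C/c2ccsc2)on1`: > 128000 nM
Compound 2 `CCC(CC)OC(=O)c1cc(/C=C/c2c(Cl)cncc2Cl)on1`: > 128000 nM

Both entries are limits of the assay and not numbers, as the summary shows: the limit of > 128000 nM in this assay, at which 2 of the 2 values shown sit. Compound 2 therefore stands at a limit, and no number is known for it.

Compound 3 `CCCCCCC(C)OC(=O)c1cc(/C=C/c2c(Cl)cncc2Cl)on1` carries 1-methylheptyl in place of the pentan-3-yl of compound 2, on an oxygen next to a carbonyl group: 1-methylheptyl in place of pentan-3-yl on an oxygen next to a carbonyl group. Among the measured compounds shown here, no measured step yet shows what a change at this place does in this assay. The expectation rests on compound 2 and its limit of > 128000 nM: no step beyond the scatter is expected, and any real movement would more likely be towards a lower number. The expected step is a number no higher from compound 2 to compound 3 (the limit leaves the size open). For compound 3 the estimated value is 128000 nM, with an expected range of 60000 nM to 200000 nM.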

Compound 3, half-maximal inhibitory concentration: > 128000 nM
Compound 3: only a limit was reported (the forecaster's own chance of this, stated with the estimate: 70%); the middle value sits exactly at the limit.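

Compound 2 and compound 3 both stand at a limit of the assay and not at a number, so no step between them can be read: the limit of > 128000 nM in this assay, at which 3 of the 3 values shown sit.

The compounds shown leave open what concentration, if any, would give half-maximal inhibition for any of them in this assay.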